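Replacing the Methylamide of Compound 3 with a Carboxylic Acid

The source may hold more compounds than are shown below. What is called first, only, known or untested is meant among the compounds shown, and "the series" means these compounds.

Measured so far:
- compound 1, `CNC(=O)/C=C/c1ccncc1-c1ccc2ccccc2c1`: 12.4 nM
- compound 2, `O=C(O)COc1ccncc1-c1ccc2ccccc2c1`: "not determined" (no result reported)
- compound 3, `CNC(=O)CCc1ccncc1-c1ccc2ccccc2c1`: 21.1 nM

All three share one core, and compound 2 differs from the others in its side chain, with no number reported for it. Among the compounds with values here, in an assay on a protein complex for inhibition of CDK8/Cyclin C (Homo sapiens), with a stated time of 1 h (on this read-out lower numbers stand for stronger inhibition and higher numbers for weaker inhibition), compound 3 gives 21.1 nM, the higher of the two numbers available, its only neighbour being compound 1 with 12.4 nM; the single measured step, a 1.7-fold higher number from compound 1 to compound 3 (0.23 log units; within the scatter), lies within the scatter, so the two compounds are on a par.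

Compound 4, `O=C(O)CCc1ccncc1-c1ccc2ccccc2c1`, differs from compound 3 in one place: hydroxy in place of methylamino on a carbonyl carbon. Within the data shown here, no measured step concerns this kind of change; the only step in hand, a 1.7-fold higher number from compound 1 to compound 3 (0.23 log units; within the scatter), touches a different part of the chain and offers no guide. Compound 2, which carries the same acid, gave no number at all. With that in mind the expectation for compound 4 is a weaker inhibition, the estimated step being a 7.1-fold higher number from compound 3 to compound 4 (0.85 log units; beyond the scatter). Compound 4 is expected to give about 150 nM, within the range 30 nM to 1500 nM.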

Compound 4, half-maximal inhibitory concentration: 50.5 nM
Compound 4: middle estimate off by 3.0-fold (0.47 log units), on the high side; the measured number falls inside the stated range.
By their numbers in this assay, from the lowest: compounds 1 and 3 (each within the scatter of the next); then compound 4.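

In this assay, within the data shown here, hydroxy in place of methylamino on the carbonyl carbon gives a 2.4-fold higher number from compound 3 to compound 4 (0.38 log units; beyond the scatter), the first step in this set to lie beyond the scatter, so the group at the end of this chain does affect the read-out. The change is modest, however: 2-carboxyethyl still gives a measurable inhibition, and set against the 2-(methylcarbamoyl)ethenyl chain it gives a 4.1-fold higher number from compound 1 to compound 4 (0.61 log units; beyond the scatter), again a modest step. Nothing available explains why the carboxylic acid gives a higher number than the methylamide.

On these data alone, whether the same swap on the 2-(methylcarbamoyl)ethenyl chain would give a step of similar size remains open. So does the outcome with a dimethylamino group or a simple amino group on the same carbonyl carbon, or with a longer chain carrying the carboxylic acid.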